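A few compounds are considered here, and "the series" means these few. Any claim that something is new, unique, unknown or untested is made for them only; others in the source may bear on it.

Values in a functional assay on T98G cells (Homo sapiens) for inhibition, read by MTT assay, with a stated time of 72 h (on this read-out higher numbers stand for weaker inhibition and lower numbers for stronger inhibition), as follows:
- compound 1 `CC1(C)CC(NC(=O)Nc2ccc(Cl)cc2)c2cc(F)ccc2O1` gives 30000 nM
- compound 2 `CC1(C)CC(NC(=O)NCc2ccccc2)c2cc(Cl)ccc2O1` gives 15000 nM
- compound 3 `CC(=O)NC1CC(C)(C)Oc2ccc(Cl)cc21` gives "not determined" (no result reported) (no result)

Compound 2 stands at 15000 nM and lies within the usual scatter of compound 1 at 30000 nM while compound 3 supplies no number for comparison.

Compound 4 `CC1(C)CC(NC(=O)NCc2ccccc2)c2cc(F)ccc2O1` is compound 2 with a single change, fluoro in place of chloro on an aromatic carbon and the rest of the structure stays the same: fluoro in place of chloro on an aromatic carbon. For the measured compounds named here, no measured pair shows this change on its own, so the evidence is thin. Going by the values given here, compound 1, the only measured compound carrying fluoro, gives 30000 nM and so offers no sign of a large shift.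

No step beyond the scatter is expected in this assay and the estimated change is a 1.3-fold higher number from compound 2 to compound 4 (0.12 log units; within the scatter) in size. For compound 4 the estimate is 20000 nM with an expected range from 8000 nM to 50000 nM as its ends.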

Compound 4, half-maximal inhibitory concentration: 49000 nM
Compound 4: the middle estimate sits 2.5-fold (0.39 log units) below what was measured, within the range that was stated.
By their numbers in this assay, from the lowest: compounds 2, 1 and 4 (each within the scatter of the next, the first and the last beyond it).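

In this assay, fluoro in place of chloro on the aromatic carbon, with benzyl held on the amide-type nitrogen, gives a 3.3-fold higher number from compound 2 to compound 4 (0.51 log units; beyond the scatter): a modest step and the only one here beyond the scatter, so the halogen at this position has a readable effect, with chloro carrying the lower number. With fluoro held constant, benzyl in place of 4-chlorophenyl on the amide-type nitrogen gives a 1.6-fold higher number from compound 1 to compound 4 (0.21 log units; within the scatter), which stays within the scatter, so this pair shows no readable effect of that swap. Nothing available explains the halogen step.

Going by these compounds, whether the same step holds with 4-chlorophenyl on the nitrogen remains open, and it rests on a single pair. On these data alone, how a methoxy group, a nitrile or an amine on this aromatic carbon would compare with chloro and fluoro also remains open.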